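This account rests on a few compounds, and the source may have more. Where it says the series, first, only, none or still open, it means among the compounds named here.

Measured so far:
- compound 1, `Cc1nc(Nc2ccc(O)cc2)c2cc[nH]c2n1`: 155000000 nM
- compound 2, `Cc1nc(NC2CCC2)c2cc[nH]c2n1`: 74100000 nM

Both compounds were tested in a functional assay on the whole organism for inhibition, with Nicotiana tabacum as the target; on this read-out lower numbers stand for stronger inhibition and higher numbers for weaker inhibition. Compound 1 gives 155000000 nM, and compound 2 gives 74100000 nM. Compound 2 therefore stands at the lowest of the two numbers, and compound 1 sits at a higher number, a gap that lies beyond the usual scatter of repeated measurements.

Compound 3, `Cc1nc(NC(C)(C)O)c2cc[nH]c2n1`, has not yet been measured. It differs from compound 2 in one place: 1-hydroxy-1-methylethyl in place of cyclobutyl on a nitrogen on an aromatic ring. Going by the values given here, since no pair of measured compounds shows what this kind of change does, there is no measured step to lean on. The two measured numbers are very close to each other, so a step of only modest size is expected here, with a slight lean toward weaker inhibition: a 1.3-fold higher number from compound 2 to compound 3 (0.13 log units; within the scatter) is the expected step. For compound 3 the estimate in this assay is 100000000 nM, within a range from 30000000 nM to 400000000 nM.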

Compound 3, half-maximal inhibitory concentration: 166000000 nM
Compound 3: the middle estimate sits 1.7-fold (0.22 log units) below what was measured; low and high end bracket the measured number.
By their numbers in this assay, from the lowest: compound 2; then compounds 1 and 3 (each within the scatter of the next).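

In this assay, putting 1-hydroxy-1-methylethyl in place of cyclobutyl on this nitrogen gives a 2.2-fold higher number from compound 2 to compound 3 (0.35 log units; beyond the scatter), so the position responds to this change, though only modestly. The two groups match in heavy atoms, but the entering one has no ring and brings an oxygen, so a change in make-up at the same heavy-atom count is enough to shift the number beyond the scatter. Nothing measured here explains the shift.

The change removes the ring and adds the hydroxyl at once, so the compounds shown cannot tell which of the two matters, or whether both do. A tert-butyl group on the same nitrogen, with neither ring nor oxygen, would help to pull these two apart.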